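A few compounds are considered here, and "the series" means these few. Any claim that something is new, unique, unknown or untested is made for them only; others in the source may bear on it.

Working notes on the series.

Of the compounds shown here, two carry numbers so far. Compound 1 `O=S(=O)(Nc1ccccn1)c1ccc(Nc2nncc3ccccc23)cc1` is tested in a functional assay on UO-31 cells (Homo sapiens) for antiproliferative activity, read by sulforhodamine B assay, with a stated time of 72 h (on this read-out higher numbers stand for weaker inhibition and lower numbers for stronger inhibition), where compound 1 gives 44 nM. Among the compounds with values here, compound 2 `COc1ccc(NC(=S)NNc2nncc3ccccc23)cc1` differs from compound 1 at more than one place, so no single step is read between them; in this assay compound 2 gives 47 nM. The two numbers sit within the usual scatter of one another, and neither compound can be set apart from the other on these data.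

Compound 3 `O=S(=O)(Nc1nccs1)c1ccc(Nc2nncc3ccccc23)cc1` has not yet been measured in this assay. It differs from compound 1 at one place only: 1,3-thiazol-2-yl in place of pyridin-2-yl on a sulfonamide nitrogen. Within the data shown here, no step between measured compounds covers this kind of change, so there is no measured precedent for its size. Given that compound 1 gives 44 nM and the change is confined to the sulfonamide nitrogen while the rest of the molecule stands unchanged, the expectation is a step no larger than the scatter, in either direction, that is a 1.1-fold higher number from compound 1 to compound 3 (0.06 log units; within the scatter). On that basis compound 3 is estimated at 50 nM, with a range from 20 nM to 130 nM.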

Compound 3, half-maximal inhibitory concentration: 12 nM
The estimate for compound 3 lay 4.2-fold (0.62 log units) above the measured number; the measured number lies below the stated range.
By their numbers in this assay, from the lowest: compound 3; then compounds 1 and 2 (each within the scatter of the next).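

Within the data shown here, the change from pyridin-2-yl to 1,3-thiazol-2-yl on a sulfonamide nitrogen brings a 3.7-fold lower number from compound 1 to compound 3 (0.56 log units; beyond the scatter) in this assay and is the first single-place step to be read. It shows that the number responds to the group on this nitrogen while the rest of the molecule stands unchanged, which the comparison of compound 1 with compound 2 could not show. The step swaps a six-membered aromatic ring with 1 hetero atom for a five-membered aromatic ring with 2 hetero atoms, so ring size and hetero atoms change together and cannot be separated here, and no measurement at hand accounts for the step.

As far as these compounds go, whether the step belongs to the 1,3-thiazol-2-yl group alone stays open, since 1,3-oxazol-2-yl, pyrimidin-2-yl, plain phenyl or a small alkyl group such as methyl on the same nitrogen would be needed to tell. From the compounds shown here alone, whether the same step holds on other cell lines also remains unknown from these compounds.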